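From Chlorofluorophenyl to Dimethoxyphenyl: An Expected Small Step

The source may report more compounds than this note shows. Statements on the series, on what has been measured and on what is new or still open speak of the compounds shown alone.

Two compounds have values in a functional assay on PC-3 cells (Homo sapiens) for cytotoxicity, read by MTT assay, with a stated time of 72 h (on this read-out higher numbers stand for weaker inhibition and lower numbers for stronger inhibition), so far. Compound 1 (`O=C(/C=C/c1ccc([N+](=O)[O-])cc1)Nc1cc2c(Nc3ccc(F)c(Cl)c3)ncnc2cc1O[C@H]1CCOC1`) gives 22800 nM and compound 2 (`COc1cc2ncnc(Nc3ccc(F)c(Cl)c3)c2cc1NC(=O)/C=C/c1ccc(F)cc1Cl`) gives 32700 nM and these two numbers lie within the usual scatter of repeated measurements, so neither compound can be ranked over the other. Compound 3 (`COc1ccc(OC)c(/C=C/C(=O)Nc2cc3c(Nc4ccc(F)c(Cl)c4)ncnc3cc2OC)c1`) differs from compound 2 in one place, on a double-bonded chain carbon bound to a double-bonded chain carbon (2,5-dimethoxyphenyl in place of 2-chloro-4-fluorophenyl on a double-bonded chain carbon bound to a double-bonded chain carbon) and has no value yet. For the measured compounds named here, no measured pair shows this swap alone, and the only guide is that compound 1 at 22800 nM and compound 2 at 32700 nM sit close together while carrying different groups. In this assay no step beyond the scatter is expected, in either direction. The expected step of a 1.3-fold lower number from compound 2 to compound 3 (0.10 log units; within the scatter) is therefore small. For compound 3 the estimated value is 26000 nM with 10000 nM to 60000 nM as the expected range.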

Compound 3, half-maximal inhibitory concentration: 28600 nM
Estimate against measurement, compound 3: 1.1-fold (0.04 log units) below; measured number inside the range.
By their numbers in this assay, from the lowest: compounds 1, 3 and 2 (each within the scatter of the next).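

In this assay, for the compounds shown here, compound 2 and compound 3 form the first pair that differs in one place alone, and the swap gives a 1.1-fold lower number from compound 2 to compound 3 (0.06 log units; within the scatter). At this position on a double-bonded chain carbon, a 2-chloro-4-fluorophenyl group with 0 hydrogen-bond acceptors can therefore give way to a 2,5-dimethoxyphenyl group with 2 hydrogen-bond acceptors, and the two compounds cannot be told apart on this read-out. Nothing shown here explains why the two compounds read alike.

Going by these compounds, both groups in this pair are substituted phenyl rings, so it remains open whether a pyridine ring, a dimethylamino group or a carboxylic acid in this place would give a step beyond the scatter. One pair also cannot show whether the same swap would read alike on a different core.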